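The compounds below may be only part of what the source reports. "The series", "measured", "known", "first", "only" and "open" are said of these compounds alone.

Measured compounds in a functional assay on the whole organism (integument) for inhibition, with Chilo suppressalis as the target, read by scintillation counting, with a stated time of 72 h; a higher number here means a weaker inhibitor, a lower number a stronger inhibitor:
compound 1, `O=C(Nc1nnc(-c2ccc(Cl)cc2)s1)c1c(F)cccc1F`: > 5010 nM
compound 2, `COc1cccc(OC)c1C(=O)Nc1nnc(-c2ccc(Cl)cc2)s1`: 58.9 nM
compound 3, `O=C(Nc1nnc(-c2ccc(Cl)cc2)s1)c1ccccc1F`: 724 nM

The value given for compound 1 is a limit of this assay, not a measured number. Among the compounds with a number, compound 3 has the highest one; compound 2 sits lower, and that gap is beyond the scatter. Compound 4, `O=C(Nc1nnc(-c2ccc(Cl)cc2)s1)c1ccccc1Br`, has not yet been measured in this assay. It differs from compound 3 in one place: bromo in place of fluoro on an aromatic carbon. Among the measured compounds shown here, only one measured step touches the same position, an at least 6.9-fold lower number from compound 1 to compound 3 (0.84 log units; beyond the scatter), and it concerns the removal of a fluoro group rather than its exchange for bromo, so it gives little direct guidance for the move to bromo. For the measured compounds named here, the values of compound 2 and compound 3 show that a ring carrying two methoxy groups gives a lower number than one carrying a single fluoro, but no step between them is computed here, and nothing measured shows how bromo behaves at this position. Without a measured step of the same kind, a change no larger than modest is expected either way. Compound 4 is estimated at 500 nM, with a range from 150 nM to 2000 nM, which means an expected step of a 1.4-fold lower number from compound 3 to compound 4 (0.16 log units; within the scatter).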

Compound 4, half-maximal inhibitory concentration: > 5010 nM
Compound 4: no number, only a limit; the forecaster's own chance of this, stated with the estimate: 5%; at least 10-fold (1.00 log units) between middle value and limit.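

Exchanging fluoro for bromo on this aromatic carbon, ortho to a large group, gives an at least 6.9-fold higher number from compound 3 to compound 4 (0.84 log units; beyond the scatter) in this assay, so this single-atom change moves the result well beyond the scatter. The earlier step showed only what happens when a fluoro group is removed at this position, whereas this one shows that the position does not treat bromo and fluoro alike, and that among the compounds shown a fluoro group cannot simply be exchanged for bromo here without a clear loss. The value of > 5010 nM for compound 4 is a limit of the assay, and the true size of the step stays unknown because the reading of compound 4 stops at that limit: the limit of > 5010 nM in this assay, at which 2 of the 4 values shown sit.

On these data alone, what a methyl group, a nitrile or an amine would give in this same place remains open, as does whether a single methoxy group there would behave more like fluoro or more like bromo. As far as these compounds go, it is also open whether the exchange of fluoro for bromo would have the same outcome on a ring that carries a second group.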